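Compound 3: 3-methylthiophen-2-yl in place of 3-chlorophenyl

The compounds below may be only part of what the source reports. "The series", "measured", "known", "first", "only" and "open" are said of these compounds alone.

- compound 1 `C=C/C=C\[C@H](C)[C@H](OC(N)=O)[C@@H](C)[C@H](O)[C@@H](C)C/C(C)=C\[C@H](C)[C@@H](O)[C@@H](C)/C=C\CCc1cccc(O)c1C` gives 490 nM
- compound 2 `C=C/C=C\[C@H](C)[C@H](OC(N)=O)[C@@H](C)[C@H](O)[C@@H](C)C/C(C)=C\[C@H](C)[C@@H](O)[C@@H](C)/C=C\CCc1cccc(Cl)c1` gives 400 nM
- compound 3 `C=C/C=C\[C@H](C)[C@H](OC(N)=O)[C@@H](C)[C@H](O)[C@@H](C)C/C(C)=C\[C@H](C)[C@@H](O)[C@@H](C)/C=C\CCc1sccc1C` is not yet measured

Going by the values given here, in a functional assay on MCF7 cells (Homo sapiens) for cytotoxicity (a lower number here means a stronger inhibitor, a higher number a weaker inhibitor), compound 2 gives 400 nM and stands level with compound 1, the only other measured compound. The change to compound 3 (3-methylthiophen-2-yl in place of 3-chlorophenyl on a saturated chain carbon, two bonds along the chain from a double-bonded chain carbon) puts 3-methylthiophen-2-yl in place of 3-chlorophenyl on a saturated chain carbon, two bonds along the chain from a double-bonded chain carbon. Among the compounds with values here, one measured step bears on it, at the same place: a 1.2-fold lower number from compound 1 to compound 2 (0.09 log units; within the scatter) with 3-chlorophenyl in place of 3-hydroxy-2-methylphenyl. This is thin evidence, as no five-membered ring has been measured here. No step beyond the scatter is expected in this assay in either direction, and the estimated step is (a 1.1-fold higher number from compound 2 to compound 3 (0.05 log units; within the scatter)). Compound 3 is expected at 450 nM (estimated range 180 nM to 1100 nM).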

Compound 3, half-maximal inhibitory concentration: 370 nM
Estimate against measurement, compound 3: 1.2-fold (0.09 log units) above, and the stated range covers the measured number.
By their numbers in this assay, from the lowest: compounds 3, 2 and 1 (each within the scatter of the next).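

In this assay, the saturated chain carbon, two bonds along the chain from a double-bonded chain carbon, also carries a five-membered aromatic ring with 1 hetero atom without a step beyond the scatter: 3-methylthiophen-2-yl in place of 3-chlorophenyl gives a 1.1-fold lower number from compound 2 to compound 3 (0.03 log units; within the scatter), and in place of 3-hydroxy-2-methylphenyl it gives a 1.3-fold lower number from compound 1 to compound 3 (0.12 log units; within the scatter). Compounds 1, 2 and 3 thus stand within the scatter of each other, so across these three end groups neither ring size nor the change of ring substituents separates the compounds. Nothing at hand explains this flat result.

Open, going by these compounds, is whether the flat result extends to end groups of another kind, such as a saturated cyclohexyl ring, or to an amine or a carboxylic acid on the ring. Also open, on these data alone, is what an unsubstituted thiophen-2-yl or a longer chain ahead of the ring would do.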